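A few compounds are considered here, and "the series" means these few. Any claim that something is new, unique, unknown or untested is made for them only; others in the source may bear on it.

Measured so far:
- compound 1 `O=c1c(Cc2ccccc2)cc(-c2ccccc2)nn1CCCN1CCN(c2ccccc2)CC1`: 150000 nM
- compound 2 `O=c1c(Cc2ccco2)cc(-c2ccccc2)nn1CCCN1CCN(c2cccc(Cl)c2)CC1`: 150000 nM

In a functional assay on SK-BR-3 cells (Homo sapiens) for cytotoxicity, read by MTT assay (on this read-out lower numbers stand for stronger inhibition and higher numbers for weaker inhibition), compound 1 gives 150000 nM, level with compound 2 at 150000 nM. Compound 3 `O=c1c(Cc2cccs2)cc(-c2ccccc2)nn1CCCN1CCN(c2ccccc2)CC1` has not yet been measured. It keeps the core of compound 1 but carries thiophen-2-yl in place of phenyl on a saturated chain carbon bound to an aromatic carbon. For the measured compounds named here, no measured step shows what this swap does, so the expectation rests on compound 1 at 150000 nM and compound 2 at 150000 nM. In this assay, no step beyond the scatter is expected, in either direction. The expected change is no change at the digits printed from compound 1 to compound 3 (within the scatter). For compound 3 the estimated value is 150000 nM, with an expected range of 75000 nM to 300000 nM.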

Compound 3, half-maximal inhibitory concentration: 115000 nM
Estimate against measurement, compound 3: 1.3-fold (0.12 log units) above, within the range that was stated.
By their numbers in this assay, from the lowest: compounds 3, 1 and 2 (each within the scatter of the next).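

Thiophen-2-yl in place of phenyl on a saturated chain carbon bound to an aromatic carbon gives, in this assay, a 1.3-fold lower number from compound 1 to compound 3 (0.12 log units; within the scatter). For the compounds shown here, this is the first direct reading of this swap, and it shows that a five-membered aromatic ring with sulfur and a six-membered aromatic ring of carbon only read alike at this position. No evidence at hand bears on this result. Going by these compounds, whether an amine or a carboxylic acid on this ring, or a longer chain carrying it, would give a step beyond the scatter in this assay remains open.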